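A few compounds are considered here, and "the series" means these few. Any claim that something is new, unique, unknown or untested is made for them only; others in the source may bear on it.

Of the compounds shown here, three have been measured in a functional assay on the whole organism (strain ICR) for inhibition, with Mus musculus as the target, with stated times of 7 days and 0.5 h, at a dose of 10 umol/kg by the intraperitoneal route; a lower number here means less inhibition, a higher number more inhibition at the dose given (going by the name of the read-out). Compound 1 `CC(=O)N1CCC(c2ccc(-c3cc(C(=O)O)cc4cc(-c5ccc(C(F)(F)F)cc5)ccc34)cc2)CC1` gives 83.3%, compound 2 `O=C(O)c1cc(O)c2ccc(-c3ccc(C(F)(F)F)cc3)cc2c1` gives 23.4%, and compound 3 `NCCCNC(=O)c1ccc(-c2cc(C(=O)O)cc(-n3cc(-c4ccc(C(F)(F)F)cc4)nn3)c2)s1` gives 81%. On these numbers compound 3 stands second highest of the three: its nearest neighbour is compound 1, whose number lies within the scatter of that of compound 3, so no order between the two can be read; the furthest is compound 2, whose number lies well below that of compound 3, beyond the scatter.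

Compound 4 `O=C(O)c1cc(-c2ccc(C3CCNCC3)cc2)cc(-n2cc(-c3ccc(C(F)(F)F)cc3)nn2)c1` has not yet been measured in this assay. It differs from compound 3 at one place, on an aromatic carbon of a six-membered aromatic ring of carbon only, meta to a carboxy group: 4-(piperidin-4-yl)phenyl in place of 5-((3-aminopropyl)carbamoyl)thiophen-2-yl on an aromatic carbon. The entering 4-(piperidin-4-yl)phenyl group recalls the substituent borne by compound 1, which reached 83.3%, while the remainder of compound 4 matches compound 3.

Since both compound 1 and compound 3 sit high and only compound 2 sits low, the step is expected to be small, at most a modest fall, and possibly none beyond the scatter. Compound 4 is therefore estimated to give 75%, with a range from 50% to 92%, which would mean a step of a number 6 percentage points lower from compound 3 to compound 4 (within the scatter).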

Compound 4, a percentage reported as inhibition, in the whole organism at one dose (the size of the read-out at that dose, not a potency): 52.4%
Compound 4: the middle estimate sits 22.6 percentage points above what was measured; the range from low to high includes it.
By their numbers in this assay, from the lowest: compound 2; then compound 4; then compounds 3 and 1 (each within the scatter of the next).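

In this assay, putting 4-(piperidin-4-yl)phenyl in place of 5-((3-aminopropyl)carbamoyl)thiophen-2-yl on an aromatic carbon, meta to a carboxy group, gives a number 28.6 percentage points lower from compound 3 to compound 4 (beyond the scatter), although both groups count the same number of heavy atoms. Within the data shown here, no earlier pair of compounds differed in one place, so this is the first single change that can be read, and it shows that a change at this position alone can move the number beyond the usual scatter. Nothing measured here bears on why the number falls.

The step exchanges the five-membered aromatic ring for a six-membered one and the 3-aminopropyl amide chain for a piperidine in one move, so the compounds shown do not tell which of these parts accounts for it. Going by these compounds, a phenyl carrying the same (3-aminopropyl)carbamoyl group would separate the ring from the chain, and a thiophen-2-yl carrying a piperidin-4-yl group would test the same question from the other side, while a longer aminoalkyl chain on the amide remains open as well.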